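Pyridin-4-yl in Place of Phenyl on Compound 3

The source may hold more compounds than are shown below. What is called first, only, known or untested is meant among the compounds shown, and "the series" means these compounds.

In a functional assay on MCF7 cells (Homo sapiens) for antiproliferative activity, read by MTT assay, with a stated time of 72 h (a higher number here means a weaker inhibitor, a lower number a stronger inhibitor), compound 1 `CC1=CC[C@H]2[C@@H]1CC=C(C)[C@@H](CC[C@H]1[C@]3(C)CC[C@H](O)C(C)(C)O[C@H]3CC[C@@]1(C)O)C2(C)C` gives > 50000 nM, which is a limit of the assay and not a number. Compound 2 `CC(=O)O[C@H]1CC[C@]2(C)[C@H](CC[C@@](C)(O)[C@H]2CC[C@@H]2C(C)=CC[C@@H]3C(C)=CC[C@@H]3C2(C)C)OC1(C)C`, with acetyl in place of hydrogen on an oxygen on a saturated carbon, gives 43500 nM. Compound 3 `CC1=CC[C@H]2[C@@H]1CC=C(C)[C@@H](CC[C@H]1[C@]3(C)CC[C@H](OC(=O)c4ccccc4)C(C)(C)O[C@H]3CC[C@@]1(C)O)C2(C)C`, with benzoyl on that oxygen, gives 23100 nM. Measured against the limit, benzoyl gives an at least 2.1-fold lower number from compound 1 to compound 3 (0.33 log units; beyond the scatter), whereas acetyl gives an at least 1.1-fold lower number from compound 1 to compound 2 (0.06 log units; that floor lies within the scatter). Compound 3 therefore stands clear of the limit but cannot be separated from the acetyl analogue.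

Compound 4 `CC1=CC[C@H]2[C@@H]1CC=C(C)[C@@H](CC[C@H]1[C@]3(C)CC[C@H](OC(=O)c4ccncc4)C(C)(C)O[C@H]3CC[C@@]1(C)O)C2(C)C` carries a single change, pyridin-4-yl in place of phenyl on a carbonyl carbon. Within the data shown here, the only measured step at that carbonyl carbon is phenyl in place of methyl, and it gave a 1.9-fold lower number from compound 2 to compound 3 (0.27 log units; within the scatter). Even that exchange of a methyl for a whole ring stayed small, and no measured compound yet carries a ring with a hetero atom. A small change is thus expected in this assay, with no firm direction and nothing beyond the scatter, and the estimated step is a 1.3-fold higher number from compound 3 to compound 4 (0.11 log units; within the scatter). Compound 4 is estimated at 30000 nM, with an expected range of 14000 nM to 50000 nM.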

Compound 4, half-maximal inhibitory concentration: > 50000 nM
Compound 4 gave a limit, no number; the forecaster's own chance of this, stated with the estimate: 25%; middle value at least 1.6-fold (0.22 log units) away from the limit.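

In this assay the identity of the ring on this carbonyl carbon turns out to matter: pyridin-4-yl in place of phenyl gives an at least 2.1-fold higher number from compound 3 to compound 4 (0.33 log units; beyond the scatter). Among these compounds, this is the first step among those at this carbonyl carbon that lies beyond the scatter, whereas phenyl in place of methyl had stayed within it. Pyridin-4-yl in place of methyl gives an at least 1.1-fold higher number from compound 2 to compound 4 (0.06 log units; that floor lies within the scatter), so that floor does not separate the two groups, and the value of compound 4 is a limit, so the full size of both steps stays unknown, and the step from compound 1, which also ends at a limit, cannot be read: the limit of > 50000 nM in this assay, at which 2 of the 4 values shown sit.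

What the compounds shown leave open is whether the ring nitrogen itself or its place in the ring decides this result, and whether a pyridin-3-yl or a thiophene ring on the same carbonyl carbon would stay with phenyl or fall with pyridin-4-yl. They also leave open whether a benzoyl carrying a chlorine or an amine on its ring, or a longer chain in place of the ring, would give a lower number than compound 3.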